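The compounds below may be only part of what the source reports. "The series", "measured", "known", "first", "only" and "open" are said of these compounds alone.

Working notes on the series.

Compound 1 `Cc1ccc(/C=C2\CCC/C(=C\c3cccc([N+](=O)[O-])c3)C2=O)cc1` stands at the high end of the three numbers available: in a functional assay on CCRF-CEM cells (Homo sapiens) for cytotoxicity, with a stated time of 72 h (a lower number here means a stronger inhibitor, a higher number a weaker inhibitor), compound 1 gives 10100 nM. Compound 2 `COc1ccc(/C=C2\CCC/C(=C\c3ccccc3[N+](=O)[O-])C2=O)cc1` gives 7450 nM in this assay, and the two values lie within the scatter of each other; compound 2 differs from compound 1 in more than one place, so its value is only a reference point. Among the measured compounds shown here, compound 3 `O=C1/C(=C/c2ccc(F)cc2)CCC/C1=C\c1ccccc1[N+](=O)[O-]` gives 1510 nM, and the single-point step a 4.9-fold lower number from compound 2 to compound 3 (0.69 log units; beyond the scatter) is the only measured step in this set.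

Compound 4 `COc1ccc(/C=C2\CCC/C(=C\c3cccc([N+](=O)[O-])c3)C2=O)cc1` differs from compound 1 by methoxy in place of methyl on an aromatic carbon. For the measured compounds named here, no measured pair isolates this change: the one step available concerns fluoro against methoxy, not methoxy against methyl, and compound 2 carries the methoxy group with the nitro group in a different arrangement. With nothing to anchor a direction, the expectation is a step of a 1.2-fold lower number from compound 1 to compound 4 (0.07 log units; within the scatter) that stays within the scatter, and compound 4 is estimated at 8500 nM in this assay, with a range from 3800 nM to 19000 nM.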

Compound 4, half-maximal inhibitory concentration in the CCRF-CEM assay: 8220 nM
Compound 4: the middle estimate sits 1.0-fold (0.01 log units) above what was measured; measured number inside the range.
By their numbers in the CCRF-CEM assay, from the lowest: compound 3; then compounds 2, 4 and 1 (each within the scatter of the next).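

Going from 4-methylphenyl to 4-methoxyphenyl, the CCRF-CEM assay shows a 1.2-fold lower number from compound 1 to compound 4 (0.09 log units; within the scatter) as the first measured pair to isolate this change. At this place on the core of compound 1, methyl and methoxy therefore cannot be told apart in cytotoxicity. In a physicochemical assay for lipophilicity (on this read-out higher numbers stand for higher lipophilicity and lower numbers for lower lipophilicity), compound 1 gives 5.06 and compound 4 gives 5.06 in a pair that shows no separation on this read-out either.

Going by these compounds, in the CCRF-CEM assay it remains open whether fluoro in place of methoxy would repeat on compound 4 a 4.9-fold lower number from compound 2 to compound 3 (0.69 log units; beyond the scatter) seen with the other nitro arrangement. Equally open, on these data alone, is how an amine or a carboxylic acid at this place would read. No supporting data are available to account for the flat result in either read-out.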